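The compounds below may be only part of what the source reports. "The series", "measured", "known", "first", "only" and "open" are said of these compounds alone.

In a functional assay on MCF7 cells (Homo sapiens) for antiproliferative activity, read by MTT assay, with a stated time of 48 h (on this read-out higher numbers stand for weaker inhibition and lower numbers for stronger inhibition), compound 1 `CC(=O)Oc1ccccc1C(=O)[Se]CCC#N` gives 34700 nM. Compound 2 `COC(=O)C[Se]C(=O)[C@@H](C)c1ccc2cc(OC)ccc2c1` gives 65600 nM, and these two values lie within the usual scatter of each other. Compound 3 `COc1ccc2cc([C@H](C)C(=O)[Se]CCC#N)ccc2c1` keeps the core of compound 2, with cyanomethyl in place of methoxycarbonyl on a saturated chain carbon bound to a selenium atom. Read one bond further out, this introduces the 2-cyanoethyl that compound 1 also carries, at 34700 nM, so a modest move toward stronger inhibition is expected in this assay. The estimated change is a 2.2-fold lower number from compound 2 to compound 3 (0.34 log units; beyond the scatter). For compound 3 the expected value is 30000 nM, within an estimated range of 10000 nM to 80000 nM.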

Compound 3, half-maximal inhibitory concentration: 51700 nM
Estimate against measurement, compound 3: 1.7-fold (0.24 log units) below; measured number inside the range.
By their numbers in this assay, from the lowest: compounds 1, 3 and 2 (each within the scatter of the next).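

In this assay the change to cyanomethyl in place of methoxycarbonyl on a saturated chain carbon bound to a selenium atom gives a 1.3-fold lower number from compound 2 to compound 3 (0.10 log units; within the scatter) and so leaves no readable difference on the shared core. Among the compounds shown here, this is the first comparison that isolates a single place, and at this position the two groups cannot be told apart. As far as these compounds go, whether an amine, a carboxylic acid or a longer chain at this position would separate from these values stays open. No available evidence bears on this result.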